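A few compounds are considered here, and "the series" means these few. Any claim that something is new, unique, unknown or untested is made for them only; others in the source may bear on it.

Among the measured compounds shown here, in a functional assay on HeLa cells (Homo sapiens) for antiproliferative activity, read by MTT assay, with a stated time of 48 h (a higher number here means a weaker inhibitor of growth, a lower number a stronger inhibitor of growth), compound 1 `COC(=O)N1N=C(c2ccccc2)CC1c1cc(OC)c(OC)c(OC)c1` gives 2180 nM and compound 2 `COC(=O)N1N=C(c2cccc(C)c2)CC1c1cc(OC)c(OC)c(OC)c1` gives 50 nM, so compound 2 holds the lower of the two numbers so far. For the measured compounds named here, the only measured step, a 44-fold lower number from compound 1 to compound 2 (1.64 log units; beyond the scatter), is large and beyond the scatter, and it is methyl in place of hydrogen on an aromatic carbon. Compound 3 `COC(=O)N1N=C(c2ccc(O)cc2)CC1c1cc(OC)c(OC)c(OC)c1` is the next case: 4-hydroxyphenyl in place of 3-methylphenyl on a carbon with a double bond to nitrogen. Going by the values given here, compound 3 thus lacks the methyl behind that single step, and no measured compound carries the 4-hydroxyphenyl group. A higher number in this assay is therefore expected, giving back much but not all of the step from compound 1. The expected change is an 8.0-fold higher number from compound 2 to compound 3 (0.90 log units; beyond the scatter). For compound 3 the estimated value is 400 nM, with an expected range from 60 nM to 2500 nM.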

Compound 3, concentration for 50% growth inhibition: 1140 nM
For compound 3 the middle estimate is 2.9-fold (0.45 log units) below the measured one; the measured number falls inside the stated range.
By their numbers in this assay, from the lowest: compound 2; then compounds 3 and 1 (each within the scatter of the next).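

In this assay, 4-hydroxyphenyl in place of 3-methylphenyl on the carbon with a double bond to nitrogen gives a 23-fold higher number from compound 2 to compound 3 (1.36 log units; beyond the scatter), so the gain seen with the methyl does not extend to every added group on this aromatic ring. Against the unsubstituted phenyl of compound 1, the hydroxy gives a 1.9-fold lower number from compound 1 to compound 3 (0.28 log units; within the scatter), which shows that adding a group here is not enough by itself and that the outcome depends on the particular substitution. Nothing available here accounts for the gap between the methyl and hydroxy compounds.

Compound 2 and compound 3 differ in both the group and its place on the aromatic ring, so the compounds shown cannot separate these two factors. They also leave open how an amine or a longer chain such as ethyl would behave on this ring.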